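Amide aryl variation on a flavonol core

The compounds below may be only part of what the source reports. "The series", "measured", "known", "first", "only" and "open" are said of these compounds alone.

Compound 2 `Cc1cccc(C(=O)Nc2cccc(-c3oc4cc(-c5ccc(F)cc5)ccc4c(=O)c3O)c2)c1` and compound 1 `Cc1ccc(C(=O)Nc2cccc(-c3oc4cc(-c5ccc(F)cc5)ccc4c(=O)c3O)c2)cc1` share a core and differ only in the aryl group on the amide carbonyl. In a functional assay on MDA-MB-231 cells (Homo sapiens) for antiproliferative activity, read by CCK-8 assay, with a stated time of 72 h (on this read-out lower numbers stand for stronger inhibition and higher numbers for weaker inhibition), compound 1 gives 4350 nM and compound 2 gives 2840 nM; the step of a 1.5-fold lower number from compound 1 to compound 2 (0.19 log units; within the scatter) is within the scatter, so compound 2 holds the lowest of two numbers without being separated from compound 1. Compound 3 `COc1ccc(C(=O)Nc2cccc(-c3oc4cc(-c5ccc(F)cc5)ccc4c(=O)c3O)c2)c(F)c1` carries the change (2-fluoro-4-methoxyphenyl in place of 3-methylphenyl on a carbonyl carbon). Among the measured compounds shown here, the only measured step on this carbonyl aryl, from compound 1 to compound 2, was within the scatter, and no measured pair speaks to a methoxy or a fluorine at this place, so no step beyond the scatter is expected in this assay. Compound 3 is therefore estimated at 3000 nM with a range of 1100 nM to 8500 nM, a step of a 1.1-fold higher number from compound 2 to compound 3 (0.02 log units; within the scatter) that is expected to stay within the scatter.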

Compound 3, half-maximal inhibitory concentration: 17600 nM
For compound 3 the middle estimate is 5.9-fold (0.77 log units) below the measured one; measured number outside the range, above it.
By their numbers in this assay, from the lowest: compounds 2 and 1 (each within the scatter of the next); then compound 3.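

In this assay the aryl group on the amide carbonyl proves able to shift the number, since the 2-fluoro-4-methoxyphenyl group gives a 6.2-fold higher number from compound 2 to compound 3 (0.79 log units; beyond the scatter) and likewise a 4.0-fold higher number from compound 1 to compound 3 (0.61 log units; beyond the scatter), both towards weaker inhibition. Among the compounds shown here, the two methylphenyl groups of compound 1 and compound 2 had stayed within the scatter of each other, so compound 3 holds the first step beyond the scatter at this place. Nothing measured here speaks to the reason for this step.

Compound 3 brings the fluorine and the methoxy in a single change, so the compounds shown do not tell what each contributes, and a 4-methoxyphenyl or a 2-fluorophenyl group alone would divide the two. Also open, as far as these compounds go, is how an amine or a carboxylic acid on this aryl ring would read.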